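The source may hold more compounds than are shown below. What is called first, only, known or untested is meant among the compounds shown, and "the series" means these compounds.

Measured so far in a functional assay on HL-60 cells (Homo sapiens) for inhibition, read by MTT assay, with a stated time of 72 h; a lower number here means a stronger inhibitor, a higher number a weaker inhibitor:

compound 1, `Cc1nc(-c2ccccc2)c(C(=O)N2CCN(c3cccc(Cl)c3)CC2)o1`: 39.2 nM
compound 2, `COc1cccc(N2CCN(C(=O)c3oc(C)nc3-c3ccccc3)CC2)c1`: 34.8 nM
compound 3, `CCc1nc(-c2cccc(F)c2)c(C(=O)N2CCN(c3cccc(Cl)c3)CC2)o1`: 317 nM

Compound 4, `CCc1nc(-c2cccc(F)c2)c(C(=O)N2CCN(c3cccc(OC)c3)CC2)o1`, is the unmeasured member of the set.

Among the measured compounds shown here, the one paired step that has been measured is from compound 1 to compound 2. It is methoxy in place of chloro on an aromatic carbon and gives a 1.1-fold lower number from compound 1 to compound 2 (0.05 log units; within the scatter). On this core, then, the exchange of chloro for methoxy leaves the number essentially where it was.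

Compound 3 sits on a different core. The difference between the core of compound 3 and the core of compound 1 is not broken down here; the two differ in more than one place. What the values show is that compound 3 gives the highest number of the three measured compounds, and its gap to compound 1 and to compound 2 is in each case beyond the usual scatter.

Compound 4 is reached from compound 3 by methoxy in place of chloro on an aromatic carbon. For the measured compounds named here, this is the same change as the one from compound 1 to compound 2, made at the same kind of place, so the only guide to its size is the earlier pair. The step of a 1.1-fold lower number from compound 3 to compound 4 (0.04 log units; within the scatter) is expected to stay within the scatter, because a 1.1-fold lower number from compound 1 to compound 2 (0.05 log units; within the scatter) showed that this exchange barely moved the number. From the compounds shown here alone, compound 4 is therefore estimated at 290 nM, with a likely range from 120 nM to 700 nM, the width reflecting that the carry-over from one core to another is untested.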

Compound 4, half-maximal inhibitory concentration: 201 nM
Estimate against measurement, compound 4: 1.4-fold (0.16 log units) above; the measured number falls inside the stated range.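

In this assay, methoxy in place of chloro on an aromatic carbon gives a 1.6-fold lower number from compound 3 to compound 4 (0.20 log units; within the scatter) and so, on the core of compound 3 as on the core of compound 1, the exchange of 3-chlorophenyl for 3-methoxyphenyl stays within the scatter. This supports carrying the change between these two cores only; two pairs say nothing about a third core, and a step within the scatter does not fix any true size for the exchange, nor does it account for the gap between the two cores. The two steps cannot be told apart on these numbers: the same change on two cores in this assay, a 1.1-fold lower number (0.05 log units; within the scatter) from compound 1 to compound 2 and a 1.6-fold lower number (0.20 log units; within the scatter) from compound 3 to compound 4, 1.4-fold (0.15 log units) apart, within the scatter of two such steps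

The cores of compound 1 and compound 3 differ in more than one place, and the compounds shown leave open how much of the gap between them belongs to each place. Also open, from the compounds shown here alone, is whether the same aromatic carbon tolerates a group of another kind, such as an amine or a carboxylic acid, and whether either core would then respond in the same way.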